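Phenyl for 2,2-dimethyl-1,3-dioxolan-4-yl: estimating compound 4

The source may hold more compounds than are shown below. What is called first, only, known or untested is meant among the compounds shown, and "the series" means these compounds.

Compound 1 `CC1(C)OC[C@H](Cn2cc(-c3ccc([N+](=O)[O-])cc3)nn2)O1` gives in a functional assay on B16 cells (Mus musculus) for cytotoxicity, read by MTT assay, with a stated time of 48 h (a higher number here means a weaker inhibitor, a lower number a stronger inhibitor), only > 100000 nM, which is a limit of the assay and not a number (the limit of > 100000 nM in this assay, at which 1 of the 3 values shown sits). Compound 2 `O=[N+]([O-])c1ccc(-c2cn(Cc3ccccc3)nn2)cc1` in this assay gives 5120 nM. The change between them is phenyl in place of 2,2-dimethyl-1,3-dioxolan-4-yl on a saturated chain carbon bound to an aromatic nitrogen, and it brought an at least 19-fold lower number from compound 1 to compound 2 (1.29 log units; beyond the scatter).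

Compound 3 `CC1(C)OC[C@H](Cn2cc(-c3ccc4ccccc4c3)nn2)O1` in this assay gives 12000 nM, the highest of the two numbers in the set. How the core of compound 3 differs from the core of compound 1 is not broken down here.

Compound 4 `c1ccc(Cn2cc(-c3ccc4ccccc4c3)nn2)cc1` has not yet been measured. For the measured compounds named here, it differs from compound 3 by phenyl in place of 2,2-dimethyl-1,3-dioxolan-4-yl on a saturated chain carbon bound to an aromatic nitrogen, the same change as the one from compound 1 to compound 2, made at the same place. The step from compound 3 to compound 4 is expected to be of the same order as the earlier one, a 13-fold lower number from compound 3 to compound 4 (1.12 log units; beyond the scatter), resting on an at least 19-fold lower number from compound 1 to compound 2 (1.29 log units; beyond the scatter), though that earlier step is only a lower bound on its own size. Compound 4 is therefore estimated at about 900 nM in this assay, between 250 nM and 4000 nM.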

Compound 4, half-maximal inhibitory concentration: 3890 nM
For compound 4 the middle estimate is 4.3-fold (0.64 log units) below the measured one; low and high end bracket the measured number.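

In this assay phenyl in place of 2,2-dimethyl-1,3-dioxolan-4-yl brings a 3.1-fold lower number from compound 3 to compound 4 (0.49 log units; beyond the scatter) and so runs in the same direction as on the core of compound 1. The direction carries over between these two cores, but the size does not: the same change on two cores in this assay, an at least 19-fold lower number (1.29 log units; beyond the scatter) from compound 1 to compound 2 and a 3.1-fold lower number (0.49 log units; beyond the scatter) from compound 3 to compound 4, at least 6.3-fold (0.80 log units) apart, beyond the scatter of two such steps
Compound 1 stands at a limit and not a number, so the earlier step is only a lower bound, the true gap may be wider still, and two cores do not show what sets the size of the step: the limit of > 100000 nM in this assay, at which 1 of the 4 values shown sits.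

The compounds shown leave open whether the step on a further core would lie nearer the larger or the smaller of these two. Also open, from the compounds shown here alone, is how a cyclohexyl group, a longer chain or a carboxylic acid would compare with phenyl on a saturated chain carbon bound to an aromatic nitrogen.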